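Amide substitution at the shared core: compound 3 to compound 4

The source may report more compounds than this note shows. Statements on the series, on what has been measured and on what is new or still open speak of the compounds shown alone.

Three compounds of the series have been run in a functional assay on the whole organism with Mus musculus as the target; a higher number here means that more compound is needed for the effect, a lower number that less compound is needed. Compound 1 `CN(C)C(=O)Cn1c(-c2ccc(C(F)(F)F)cc2)nc2cccnc21` gives 3.2 mg/kg. Compound 2 `CN(C)C(=O)Cn1c(-c2ccc(Br)o2)nc2cccnc21` gives 100 mg/kg. Compound 3 `CCCN(C)C(=O)Cn1c(-c2ccc(Cl)cc2)nc2cccnc21` gives 11.6 mg/kg, the second highest of the three numbers; its gap to compound 1 and its gap to compound 2 both lie beyond the usual scatter, with compound 1 nearest and compound 2 furthest from it.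

Compound 4 `CN(C)CCNC(=O)Cn1c(-c2ccc(Cl)cc2)nc2cccnc21` is not yet measured in this assay. It differs from compound 3 in one place: (2-(dimethylamino)ethyl)amino in place of methyl(propyl)amino on a carbonyl carbon. Going by the values given here, no pair of measured compounds shows this kind of change, so no step of the same sort is known; the measured compounds differ from one another in several places at once.

For compound 4 the step of a 1.0-fold higher number from compound 3 to compound 4 (0.01 log units; within the scatter) is expected to stay within the usual scatter, with no direction claimed. Compound 4 is estimated at 12 mg/kg, within a range from 4 mg/kg to 40 mg/kg.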

Compound 4, dose for half-maximal effect: 62 mg/kg
Compound 4: the middle estimate sits 5.2-fold (0.71 log units) below what was measured, and the stated range ends below it.
By their numbers in this assay, from the lowest: compound 1; then compound 3; then compounds 4 and 2 (each within the scatter of the next).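

Working notes on the amide position: the carbonyl carbon substituent is not a silent position in this assay. Going by these compounds alone, with the rest of the molecule unchanged, (2-(dimethylamino)ethyl)amino in place of methyl(propyl)amino gives a 5.3-fold higher number from compound 3 to compound 4 (0.73 log units; beyond the scatter), so this is the first single-place step, and it lies beyond the scatter. Nothing at hand explains the direction of this step.

The change alters two features at once, the amide hydrogen and the terminal dimethylamino group, and the compounds shown do not separate them. On the same carbonyl carbon, a plain butylamino group would carry the amide hydrogen without the terminal amine, while a (2-(dimethylamino)ethyl)(methyl)amino group would carry the terminal amine without the amide hydrogen.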